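Fluorinated aryl amides on a shared thiazole-free core: compound 3

The source may report more compounds than this note shows. Statements on the series, on what has been measured and on what is new or still open speak of the compounds shown alone.

Compound 1, `CN(C(=O)NC(=O)c1ccccc1F)c1nc(C(F)(F)F)c(C(=O)N/N=C/c2cc(C(F)(F)F)cc(C(F)(F)F)c2)s1`, gives 4.47 ug/mL in a functional assay on HepG2 cells (Homo sapiens) for inhibition, read by MTT assay, with a stated time of 72 h; a lower number here means a stronger inhibitor, a higher number a weaker inhibitor. Compound 2, `CN(C(=O)NC(=O)c1ccc(C(F)(F)F)cc1)c1nc(C(F)(F)F)c(C(=O)N/N=C/c2cc(C(F)(F)F)cc(C(F)(F)F)c2)s1`, gives 8.35 ug/mL in this assay.

Among the two measured numbers, compound 2 holds the higher one, but its only neighbour is compound 1, and the step of a 1.9-fold higher number from compound 1 to compound 2 (0.27 log units; within the scatter) keeps the two within the scatter of each other, so no order between them can be claimed. Compound 3, `CN(C(=O)NC(=O)c1c(F)cccc1F)c1nc(C(F)(F)F)c(C(=O)N/N=C/c2cc(C(F)(F)F)cc(C(F)(F)F)c2)s1`, is not yet measured. It differs from compound 2 by 2,6-difluorophenyl in place of 4-(trifluoromethyl)phenyl on a carbonyl carbon. Going by the values given here, the only measured step that bears on this change is a 1.9-fold higher number from compound 1 to compound 2 (0.27 log units; within the scatter), which swapped one fluorinated phenyl ring for another at the same carbonyl carbon and produced nothing beyond the scatter. On that basis, the step of a 1.5-fold lower number from compound 2 to compound 3 (0.18 log units; within the scatter) is expected to stay within the scatter as well. Compound 3 is therefore estimated at 5.5 ug/mL, with a likely range from 2.5 ug/mL to 12 ug/mL in this assay.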

Compound 3, half-maximal inhibitory concentration: 6.28 ug/mL
Estimate against measurement, compound 3: 1.1-fold (0.06 log units) below; low and high end bracket the measured number.
By their numbers in this assay, from the lowest: compounds 1, 3 and 2 (each within the scatter of the next).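

In this assay, the step of a 1.3-fold lower number from compound 2 to compound 3 (0.12 log units; within the scatter) is a third comparison at this carbonyl carbon, and it also stays small. Fluoro in place of hydrogen on an aromatic carbon, the smallest change so far, gives a 1.4-fold higher number from compound 1 to compound 3 (0.15 log units; within the scatter) and likewise does not separate the two compounds, so 2-fluorophenyl, 2,6-difluorophenyl and 4-(trifluoromethyl)phenyl all read alike at this position. Nothing available here accounts for this sameness.

From the compounds shown here alone, all three rings carry only fluoro or trifluoromethyl groups, so it remains open whether an amine or a carboxylic acid on the phenyl ring, or a plain alkyl chain in place of that ring, would move the number beyond the scatter. Going by these compounds, whether changes elsewhere on the shared core would do so is also open.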